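Removing a chloro from the benzamide of compound 2

The source may hold more compounds than are shown below. What is called first, only, known or untested is meant among the compounds shown, and "the series" means these compounds.

Measured compounds:
compound 1, `O=C(Nc1cccc(-n2cc(-c3ccncc3)c(-c3ccc(Cl)c(O)c3)n2)c1)Nc1ccc(Cl)c(Cl)c1`, 1050 nM
compound 2, `COc1cc(-c2nn(-c3cccc(NC(=O)c4ccc(Cl)c(C(F)(F)F)c4)c3)cc2-c2ccncc2)ccc1Cl`, 2420 nM

In a functional assay on OVCAR-3 cells (Homo sapiens) for inhibition, read by sulforhodamine B assay, with a stated time of 48 h (a higher number here means a weaker inhibitor of growth, a lower number a stronger inhibitor of growth), compound 1 gives 1050 nM. In this assay compound 2 gives 2420 nM, the higher of the two numbers, and the gap between compound 1 and compound 2 lies beyond the scatter. Among the measured compounds shown here, no pair of measured compounds differing in a single place is available, so no measured step guides the next change.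

Compound 3, `COc1cc(-c2nn(-c3cccc(NC(=O)c4cccc(C(F)(F)F)c4)c3)cc2-c2ccncc2)ccc1Cl`, is not yet measured. It differs from compound 2 by hydrogen in place of chloro on an aromatic carbon. For the measured compounds named here, there is no precedent among the measured compounds for this change, so the expected step in this assay is uncertain; a modest rise in the number is expected, though a step within the scatter cannot be excluded. The expected step is a 1.7-fold higher number from compound 2 to compound 3 (0.22 log units; within the scatter). For compound 3 the estimate in this assay is 4000 nM, with a range from 1500 nM to 12000 nM.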

Compound 3, concentration for 50% growth inhibition: 1200 nM
The estimate for compound 3 lay 3.3-fold (0.52 log units) above the measured number; the whole stated range lies above it.
By their numbers in this assay, from the lowest: compounds 1, 3 and 2 (each within the scatter of the next, the first and the last beyond it).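

In this assay, among the compounds shown here, going from the 4-chloro-3-(trifluoromethyl)phenyl to the 3-(trifluoromethyl)phenyl gives a 2.0-fold lower number from compound 2 to compound 3 (0.30 log units; within the scatter), the first step that can be read across a single place. The chloro on this aromatic carbon, ortho to a trifluoromethyl group and para to a large group, can therefore be replaced by hydrogen without a change in growth inhibition that stands clear of the scatter. Nothing measured here offers an explanation for this result.

As far as these compounds go, whether a fluoro, a methoxy or an amine on the same aromatic carbon would move the number beyond the scatter remains open. What the trifluoromethyl group itself contributes also remains open, as no step shown touches it.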